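A few compounds are considered here, and "the series" means these few. Any claim that something is new, unique, unknown or untested is made for them only; others in the source may bear on it.

In a functional assay on PC-3 cells (Homo sapiens) for antiproliferative activity, read by MTT assay, tested at 5 uM (on this read-out lower numbers stand for a weaker effect and higher numbers for a stronger effect at the one concentration tested), compound 1 `COc1ccc(C2OC(c3cc(OC)c(OC)c(OC)c3)=NN2C(C)=O)c(OC)c1` gives 92%.
In this assay compound 2 `COc1cc(C2=NN(C(C)=O)C(c3cccc(OC)c3OC)O2)cc(OC)c1OC` gives 58.2%.
In this assay compound 3 `COc1ccc(OC)c(C2OC(c3cc(OC)c(OC)c(OC)c3)=NN2C(C)=O)c1` gives 43.2%.

Compound 3 stands lowest of the three: a number 15 percentage points lower from compound 2 to compound 3 (beyond the scatter) and a number 48.8 percentage points lower from compound 1 to compound 3 (beyond the scatter). Compound 4 `COc1cc(C2=NN(C(C)=O)C(c3ccc(Cl)c(Cl)c3)O2)cc(OC)c1OC` is the next step from it: 3,4-dichlorophenyl in place of 2,5-dimethoxyphenyl on a saturated ring carbon. Within the data shown here, no measured step swaps methoxy groups for chlorines; the three known steps, a number 33.8 percentage points lower from compound 1 to compound 2 (beyond the scatter), a number 48.8 percentage points lower from compound 1 to compound 3 (beyond the scatter) and a number 15 percentage points lower from compound 2 to compound 3 (beyond the scatter), only move methoxy groups around the ring, yet each changed the read-out clearly. Changing this aryl ring therefore matters, but the direction for compound 4 cannot be read from the data. For compound 4 the expected step is a number 11.8 percentage points higher from compound 3 to compound 4 (beyond the scatter), an estimate with wide uncertainty. Compound 4 is estimated at 55%, between 20% and 90%.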

Compound 4, a percentage reported as inhibition, at one concentration (the size of the read-out at that concentration, not a potency): 26.1%
Beside the measured number, compound 4's estimate is 28.9 percentage points above it, within the range that was stated.
By their numbers in this assay, from the lowest: compound 4; then compound 3; then compound 2; then compound 1.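

Replacing the methoxy-bearing ring with 3,4-dichlorophenyl, a change of substituent rather than a move of methoxy groups, lowers the number in this assay in all three comparisons (a number 17.1 percentage points lower from compound 3 to compound 4 (beyond the scatter); a number 32.1 percentage points lower from compound 2 to compound 4 (beyond the scatter); a number 65.9 percentage points lower from compound 1 to compound 4 (beyond the scatter)). Compound 4 therefore ranks below every dimethoxyphenyl compound shown, so the two chlorines at this position do not match any of those methoxy patterns. Nothing available explains this drop. As far as these compounds go, it remains open how an amine or a carboxylic acid on this ring would compare. From the compounds shown here alone, whether a single chlorine would behave like the two chlorines also remains open.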